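Working notes: 3-cyanophenyl to 2-cyanophenyl swap

The compounds below may be only part of what the source reports. "The series", "measured", "known", "first", "only" and "open" are said of these compounds alone.

Measured in a physicochemical assay for solubility, measured as kinetic solubility, at pH 6.5; on this read-out higher numbers stand for higher solubility and lower numbers for lower solubility:
- compound 1 `C[C@@H](c1c[nH]c2ncccc12)c1nnc2ccc(-c3cnn(C)c3)nn12`: 150000 nM
- compound 2 `Fc1ccc(-c2ccc3nnc(Cc4ccc5ncccc5c4)n3n2)cc1F`: 11500 nM
- compound 3 `C[C@@H](c1ccc2ncccc2c1)c1nnc2ccc(-c3cccc(C#N)c3)nn12`: 32500 nM

In this assay, compound 3 stands second highest of the three at 32500 nM. Compound 2 lies lower and compound 1 lies higher, and both gaps are beyond the scatter.

The next compound to be read is compound 4 `C[C@@H](c1ccc2ncccc2c1)c1nnc2ccc(-c3ccccc3C#N)nn12`. It carries 2-cyanophenyl in place of 3-cyanophenyl on an aromatic carbon of a six-membered aromatic ring with 2 nitrogen, part of a fused or bridged system of two rings (2-cyanophenyl in place of 3-cyanophenyl on an aromatic carbon). The two compounds have the same atoms, joined differently.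

Among the compounds with values here, no two measured compounds differ in one place only, so the series gives no direct guide to the size of this change. With nothing measured to point either way, no step beyond the scatter is expected in this assay. The estimated change a 1.2-fold higher number from compound 3 to compound 4 (0.07 log units; within the scatter) is small and upward, and the range around it is kept wide. For compound 4 the expected value is 38000 nM, with an estimated range from 14000 nM to 100000 nM.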

Compound 4, solubility: 213000 nM
Beside the measured number, compound 4's estimate is 5.6-fold (0.75 log units) below it; measured number outside the range, above it.
By their numbers in this assay, from the lowest: compound 2; then compound 3; then compounds 1 and 4 (each within the scatter of the next).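

In this assay, within the data shown here, exchanging 3-cyanophenyl for 2-cyanophenyl gives a 6.6-fold higher number from compound 3 to compound 4 (0.82 log units; beyond the scatter), the first step that can be read across a single place. It shows that at this position, on an aromatic carbon of the six-membered aromatic ring with 2 nitrogen, the two cyanophenyl isomers are not interchangeable, even though the rest of the molecule stays the same. The two groups match in heavy atoms, ring, triple bond, hydrogen-bond acceptor count and charge, so the step goes with the place of the nitrile on the phenyl ring, and no measurement at hand says why it arises.

Still open, as far as these compounds go, is whether the step belongs to the nitrile or extends to other groups on the phenyl ring, such as a methoxy group or a primary amine, and how 4-cyanophenyl would compare with the two isomers. From the compounds shown here alone, it is also open whether 2-cyanophenyl gives a step of similar size on a compound with a different linking group or a different bicyclic substituent, as a single pair cannot settle this.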